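An amide gives way to a urea on a shared core

The compounds below may be only part of what the source reports. "The series", "measured", "known", "first", "only" and "open" are said of these compounds alone.

Compound 1 `COc1ccc(-c2cnc3nc(N)nc(N4CCN(C(=O)c5ccccc5)CC4)c3n2)cc1OC` carries a benzoyl group on a ring nitrogen of the shared core. In a functional assay on cells (T-cell, Homo sapiens) for inhibition (a higher number here means a weaker inhibitor, a lower number a stronger inhibitor), compound 1 gives 400 nM. Compound 2 `COc1ccc(-c2cnc3nc(N)nc(OC(C)C)c3n2)cc1OC`, which bears a quite different side chain at that place on the core, gives 400 nM in this assay, a number level with compound 1 within the scatter; together the two hold the lowest values of the three measured. Compound 3 `CCOc1ccc(-c2cnc3nc(N)nc(OC(C)C)c3n2)cc1` is a close relative of compound 2; in this assay compound 3 gives 10000 nM, a far higher number and so the weakest inhibitor of the set.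

Compound 4 `COc1ccc(-c2cnc3nc(N)nc(N4CCN(C(=O)NCc5ccc(F)cc5)CC4)c3n2)cc1OC` has not yet been measured. Relative to compound 1 it carries (4-fluorobenzyl)amino in place of phenyl on a carbonyl carbon; cut one bond further out, the change reads benzoyl to (4-fluorobenzyl)carbamoyl. Going by the values given here, no measured pair shows this change, so no step can be leaned on. Compound 1 at 400 nM and compound 2 at 400 nM sit level despite very different groups at this place, which suggests that the group there does not set the value strongly. A step no larger than the usual scatter is expected, a 1.3-fold higher number from compound 1 to compound 4 (0.10 log units; within the scatter), with only a slight lean toward a weaker inhibitor. Compound 4 is estimated at 500 nM in this assay, within a range from 150 nM to 1600 nM.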

Compound 4, half-maximal inhibitory concentration: 37 nM
Beside the measured number, compound 4's estimate is 14-fold (1.13 log units) above it; the whole stated range lies above it.
By their numbers in this assay, from the lowest: compound 4; then compounds 1 and 2 (each within the scatter of the next); then compound 3.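

Putting (4-fluorobenzyl)amino in place of phenyl on a carbonyl carbon gives an 11-fold lower number from compound 1 to compound 4 (1.03 log units; beyond the scatter) in this assay, so the group at this place can strongly change the value, which the level values of compound 1 and compound 2 did not reveal. The change turns an amide into a urea, but it also brings in a fluorine and a longer link to the aromatic ring, and this single step cannot show which of these parts matters. Nothing measured here explains the step.

On these data alone, it remains open whether a plain benzylamino group, without the fluorine, or a 4-chlorobenzylamino group would give a similar number. Phenylamino, with a shorter link, and benzyl, with no urea nitrogen, would also separate the roles of the chain and the amide hydrogen.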